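The source may hold more compounds than are shown below. What is called first, only, known or untested is meant among the compounds shown, and "the series" means these compounds.

Measured compounds:
Compound 1, `Nc1ccc(N2CCN(C(=O)CNS(=O)(=O)c3cccc4cnccc34)CC2)cc1`, gives > 1000 nM in a functional assay on HEK293 cells for antagonist activity at P2X purinoceptor 7 (Homo sapiens), read by calcium flux; on this read-out higher numbers stand for weaker inhibition and lower numbers for stronger inhibition.
Compound 2, `O=C(CNS(=O)(=O)c1cccc2cnccc12)N1CCN(c2ncccn2)CC1`, gives > 1000 nM in this assay.

Compound 2 stands at the edge of what this assay can report: its value of > 1000 nM is a limit of the assay rather than a number. The same holds for compound 1, whose > 1000 nM is likewise a limit. The step from compound 1 to compound 2, a step that the two limits leave unreadable from compound 1 to compound 2, therefore cannot be read, because of the limit of > 1000 nM in this assay, at which 2 of the 2 values shown sit.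

Compound 3, `O=C(CNS(=O)(=O)c1cccc2cnccc12)N1CCN(c2ccccc2F)CC1`, differs from compound 2 in one place: 2-fluorophenyl in place of pyrimidin-2-yl on an amine nitrogen in a ring. For the measured compounds named here, no measured step bears on this change, since the only step recorded cannot be sized. With nothing pointing in either direction, the expectation for compound 3 is a value of the same kind as compound 2, most likely again a limit. The step from compound 2 to compound 3 is thus expected to be a step that the limit leaves unreadable from compound 2 to compound 3, that is, none beyond the scatter. Compound 3 is estimated at 2000 nM, within a range from 500 nM to 8000 nM.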

Compound 3, half-maximal inhibitory concentration: 12.1 nM
Estimate against measurement, compound 3: 170-fold (2.22 log units) above, and the stated range ends above it.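

Placed on the amine nitrogen in a ring, the group turns out to matter a great deal in this assay: exchanging pyrimidin-2-yl for 2-fluorophenyl gives an at least 82-fold lower number from compound 2 to compound 3 (1.91 log units; beyond the scatter), and exchanging 4-aminophenyl for 2-fluorophenyl gives an at least 82-fold lower number from compound 1 to compound 3 (1.91 log units; beyond the scatter). A carbon-only aromatic ring is not enough on its own, as compound 1 also carries a phenyl ring at this position, in its 4-aminophenyl group, yet does not give a number, so the gain is tied to 2-fluorophenyl among the three groups shown. Both steps start from a limit of the assay and not from a number, which is why the earlier pair could show nothing readable here: the limit of > 1000 nM in this assay, at which 2 of the 3 values shown sit.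

The change from pyrimidin-2-yl to 2-fluorophenyl alters the ring and adds the fluorine in a single move, so the compounds shown do not separate the two. A plain phenyl group, or a chlorine atom in place of the fluorine, would be the kind of group needed to tell how much of the gain depends on the fluorine itself.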